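This account rests on a few compounds, and the source may have more. Where it says the series, first, only, none or still open, it means among the compounds named here.

Of the compounds shown here, three have been measured in an assay for displacement of a labelled ligand from Adrenergic receptor alpha-1 (Homo sapiens); a higher number here means a weaker inhibitor, a lower number a stronger inhibitor. Compound 2, `Cn1c(=O)cnn(CCCCN2CCN(c3ccccc3)CC2)c1=O`, gives 64 nM and holds the lowest of the three numbers. Within the data shown here, compound 1, `Cn1c(=O)cnn(CCCCN2CCN(c3ccccc3OCCCF)CC2)c1=O`, gives 280 nM; the only single-point step among the measured compounds runs between these two, and it amounts to a 4.4-fold lower number from compound 1 to compound 2 (0.64 log units; beyond the scatter), arising from hydrogen taking the place of 3-fluoropropoxy on an aromatic carbon. Among the measured compounds shown here, compound 3, `COc1ccc(N2CCN(CCCCn3ncc(=O)n(C)c3=O)CC2)c(C#N)c1`, gives 380 nM; no single-point step links it to compound 2, so its value can only be set beside that of compound 2 as a higher number.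

Compound 4, `Cn1c(=O)cnn(CCCCN2CCN(c3ccccn3)CC2)c1=O`, differs from compound 2 in one place: pyridin-2-yl in place of phenyl on an amine nitrogen in a ring. For the measured compounds named here, the one recorded step alters a substituent on the aromatic ring, not the ring itself, so it offers little direct guidance for this change. The expectation is therefore that compound 4 stays fairly close to compound 2, most likely with a somewhat higher number, though a result within the usual scatter cannot be ruled out. The step that this estimate implies is expected to be a 3.1-fold higher number from compound 2 to compound 4 (0.49 log units; beyond the scatter). For compound 4 the expected value is 200 nM, with a range from 60 nM to 700 nM.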

Compound 4, inhibition constant: 262 nM
Compound 4: the middle estimate sits 1.3-fold (0.12 log units) below what was measured, within the range that was stated.
By their numbers in this assay, from the lowest: compound 2; then compounds 4, 1 and 3 (each within the scatter of the next).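

Among these compounds, until now, the only single-point change in this assay removed a substituent from the aromatic ring, leaving the ring itself in place. Among the compounds shown here, this result is the first to alter the ring on the amine nitrogen: pyridin-2-yl keeps the same count of heavy atoms as phenyl, but one ring carbon gives way to a nitrogen that counts as a hydrogen-bond acceptor, and this exchange produces a 4.1-fold higher number from compound 2 to compound 4 (0.61 log units; beyond the scatter), so this position responds to a change within the ring as well as to a substituent on it. No measurement among these compounds accounts for the size or direction of this step.

As far as these compounds go, it remains open whether the higher number depends on having a nitrogen in the ring at all or on where that nitrogen sits, a question that pyridin-3-yl and pyridin-4-yl on the same amine nitrogen could address. A pyrimidin-2-yl ring, with a second ring nitrogen, could show whether adding another such atom moves the number further, while a cyclohexyl ring could show whether this position needs an aromatic ring at all.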